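From a Methylthiophene to a Pyridine: an Expected Shift

The source may hold more compounds than are shown below. What is called first, only, known or untested is meant among the compounds shown, and "the series" means these compounds.

Compound 1, `CCN(Cc1ccc(C)s1)C(=O)COc1ccc(C)cc1`: 178 nM
Compound 2, `Cc1ccc(OCC(=O)N(C)Cc2cccs2)cc1`: 400 nM

Both measured compounds were tested in an assay on HEK293 cells for agonist activity at transient receptor potential cation channel subfamily M member 8 (Homo sapiens), read by fluorescence and calcium flux, with a stated time of 15 min; a higher number here means that more compound is needed for the effect, a lower number that less compound is needed. Among these two numbers, compound 1 stands lowest; its nearest neighbour is compound 2, whose number lies higher by a gap beyond the usual scatter, so compound 1 is the more potent of the pair.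

Compound 3, `CCN(Cc1cccnc1)C(=O)COc1ccc(C)cc1`, has not yet been measured. It differs from compound 1 in a single place: pyridin-3-yl in place of 5-methylthiophen-2-yl on a saturated chain carbon bound to an amide-type nitrogen. Among the compounds with values here, no measured pair in this set shows the same change, so nothing here tells directly how large such a step is. The shift is nonetheless expected to move the number upward: the step of a 3.9-fold higher number from compound 1 to compound 3 (0.59 log units; beyond the scatter) is the estimated change, more than the scatter allows. Compound 3 is accordingly estimated at 700 nM, within a range from 250 nM to 2500 nM.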

Compound 3, half-maximal effective concentration: 15400 nM
Compound 3: the middle estimate sits 22-fold (1.34 log units) below what was measured, outside the stated range (above it).
By their numbers in this assay, from the lowest: compound 1; then compound 2; then compound 3.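

In this assay, replacing 5-methylthiophen-2-yl with pyridin-3-yl on a saturated chain carbon bound to an amide-type nitrogen gives an 87-fold higher number from compound 1 to compound 3 (1.94 log units; beyond the scatter), showing that the number at this position is highly sensitive to the identity of the aromatic group. The two groups match in heavy-atom count, hydrogen-bond donors and acceptors, and net charge, so these counts alone do not account for a step of this size. No available evidence explains the rise.

The change alters the ring size, the hetero atom and the methyl group at once, so the compounds shown cannot assign the rise to any one of these. A plain thiophen-2-yl or a phenyl ring at the same position would help separate these contributions.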